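Dimethoxyphenyl for Dichlorophenyl on the Carbonyl Carbon

This account rests on a few compounds, and the source may have more. Where it says the series, first, only, none or still open, it means among the compounds named here.

Compound 1 `COc1cc(-c2cc(/C=C/C(=O)c3ccc(Cl)c(Cl)c3)[nH]n2)cc(OC)c1OC` holds the higher of the two numbers recorded in a functional assay on U-251 cells (Homo sapiens) for cytotoxicity, read by sulforhodamine B assay, with a stated time of 48 h, tested at 0.1 uM; a lower number here means a stronger effect, a higher number a weaker effect of the compound at the concentration tested: compound 1 gives 95%. Compound 2 `COc1ccc(-c2cc(/C=C/C(=O)c3cc(OC)c(OC)c(OC)c3)[nH]n2)cc1OC` sits close by; in this assay compound 2 gives 92%, a gap within the scatter, so no order between them is claimed. Compound 3 `COc1ccc(C(=O)/C=C/c2cc(-c3cc(OC)c(OC)c(OC)c3)n[nH]2)cc1OC` is the untested partner of compound 1; the change is 3,4-dimethoxyphenyl in place of 3,4-dichlorophenyl on a carbonyl carbon. Among the measured compounds shown here, no measured step covers this change, but since compound 2 gives 92% with methoxy groups on the ring at the carbonyl carbon, the step of a number 2 percentage points lower from compound 1 to compound 3 (within the scatter) is expected to be none beyond the scatter. For compound 3 the estimate in this assay is 93%, range 82% to 102%.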

Compound 3, a percentage reported as activity, at one concentration (the size of the read-out at that concentration, not a potency): 95%
Compound 3: the middle estimate sits 2 percentage points below what was measured; the measured number falls inside the stated range.
By their numbers in this assay, from the lowest: compounds 2, 1 and 3 (each within the scatter of the next).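

Among the compounds shown here, on the carbonyl carbon, 3,4-dimethoxyphenyl in place of 3,4-dichlorophenyl gives no change at the digits printed from compound 1 to compound 3 (within the scatter) in this assay, the first direct reading of this change. At this single concentration, the read-out does not separate the two groups. No available data bear on the reason for this result.

Still open, on these data alone, is whether a ring carrying an amine or a carboxylic acid on the carbonyl carbon would shift the read-out. Also open, as far as these compounds go, is whether compound 1 and compound 3 would separate at other concentrations.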